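The source may report more compounds than this note shows. Statements on the series, on what has been measured and on what is new or still open speak of the compounds shown alone.

Compound 1 `CC/C=C\C/C=C\C/C=C\CCCCCCCc1cc(=O)c2c(O)cc(O)cc2o1` and compound 2 `CC/C=C\C/C=C\C/C=C\CCCCCCCc1cc(=O)c2c(O)c(C)c(O)cc2o1` share one core and were both tested in a functional assay on MDA-MB-231 cells (Homo sapiens) for antiproliferative activity, read by MTT assay; on this read-out lower numbers stand for stronger inhibition and higher numbers for weaker inhibition. Compound 1 gives 6790 nM, and compound 2 gives 6790 nM. The two structures differ by methyl in place of hydrogen on an aromatic carbon, and the step of no change at the digits printed from compound 1 to compound 2 (within the scatter). Compound 3 `CCCCCCCCCCCCCCCc1cc(=O)c2c(O)cc(OCOC)c(C)c2o1` is built on a different core; the difference between the two cores is not broken down here. In this assay compound 3 reaches only a limit of the assay, > 87000 nM. Compound 4 `CCCCCCCCCCCCCCCc1cc(=O)c2c(O)c(C)c(OCOC)c(C)c2o1` has not been measured; it differs from compound 3 by methyl in place of hydrogen on an aromatic carbon, the same kind of change as before, though here the place is ortho to a hydroxy group, ortho to a methoxymethoxy group and meta to a methyl group rather than ortho to two hydroxy groups. The expected step is a step that the limit leaves unreadable from compound 3 to compound 4, beside the measured no change at the digits printed from compound 1 to compound 2 (within the scatter). This expectation rests on the step of no change at the digits printed from compound 1 to compound 2 (within the scatter). Compound 4 is therefore estimated at 100000 nM, between 40000 nM and 250000 nM, and may again be reported only as a limit.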

Compound 4, half-maximal inhibitory concentration: > 87000 nM
Compound 4 ended at the assay's limit; the forecaster's own chance of this, stated with the estimate: 80%; the middle value is on the limit's open side.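

Compound 3 and compound 4 both stop at a limit of the assay rather than a number, so no step can be read between them: the limit of > 87000 nM in this assay, at which 2 of the 4 values shown sit. As far as these compounds go, whether the added methyl changes activity on this core stays open.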